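Cytotoxicity of Two Fused-Ring Amines and a New Analog

The source may hold more compounds than are shown below. What is called first, only, known or untested is meant among the compounds shown, and "the series" means these compounds.

Compound 1 `c1ccc(-c2ccc3c(NCCCNCc4ccco4)ccnc3c2)cc1` gives 5920 nM
Compound 2 `COc1cccc(CNCCCNc2ccnc3cc(-c4cc(C(F)(F)F)cc(C(F)(F)F)c4)ccc23)c1O` gives 940 nM

In an ADME assay on HepG2 cells (Homo sapiens) for cytotoxicity, read by luminescence, CellTiter-Glo and ATP content, with a stated time of 72 h (on this read-out lower numbers stand for an effect already at smaller amounts and higher numbers for an effect only at larger amounts of compound), compound 1 stands at the highest of the two numbers, with 5920 nM. Compound 2, whose number is 940 nM, lies lower by a margin beyond the scatter, so of the two, compound 2 is the one that shows an effect at the smaller amount. The two compounds differ in more than one place, so no single structural step can be read from that pair.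

Compound 3 `Cc1cc(C)cc(Cc2ccc3c(NCCCNCc4ccco4)ccnc3c2)c1` has not yet been measured. It differs from compound 1 in one place: 3,5-dimethylbenzyl in place of phenyl on an aromatic carbon. Going by the values given here, no measured pair shows this change, so the size of the step is uncertain. Compound 3 is expected to show a step of a 1.5-fold lower number from compound 1 to compound 3 (0.17 log units; within the scatter) that is small and, if anything, toward a lower number, since the measured pair gives no ground for a large shift. The estimate for compound 3 in this assay is 4000 nM, within a range from 1500 nM to 11000 nM.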

Compound 3, half-maximal effective concentration: 6270 nM
For compound 3 the middle estimate is 1.6-fold (0.20 log units) below the measured one; the range from low to high includes it.
By their numbers in this assay, from the lowest: compound 2; then compounds 1 and 3 (each within the scatter of the next).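

Going by these compounds alone, replacing phenyl with 3,5-dimethylbenzyl on an aromatic carbon of the shared core gives a 1.1-fold higher number from compound 1 to compound 3 (0.02 log units; within the scatter) in this assay, the first step that can be read at this position, since the earlier pair differed in more than one place. The entering group brings 9 heavy atoms where the leaving one had 6, and both carry one six-membered aromatic ring of carbon only and no hydrogen-bond donors or acceptors, so this position accepts the larger carbon-only group with no separation between the two compounds on this read-out. Nothing measured here bears on why the two compounds read alike.

This single step leaves open whether the same result would hold for groups of another kind on this carbon, such as a carboxylic acid, a primary amine or a nitrile, and whether an unsubstituted benzyl would read the same as 3,5-dimethylbenzyl. It also leaves open whether the same exchange would give a comparable step on the core of compound 2, which carries a different side chain and a different aromatic group.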